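The source may report more compounds than this note shows. Statements on the series, on what has been measured and on what is new or still open speak of the compounds shown alone.

The measured compounds in brief:

Compound 1, `O[C@@H]1[C@H](O)[C@@H]2C[C@@H]2[C@H]1n1cnc2c(NC3CCCCCC3)nc(Cl)nc21`, gives in an assay on CHO cells for displacement of a labelled ligand from adenosine receptor A1 (Homo sapiens), read by scintillation counting, with a stated time of 60 min (a higher number here means a weaker inhibitor, a lower number a stronger inhibitor), a value of 230 nM.
Compound 2, `O[C@@H]1[C@H](O)[C@@H]2C[C@@H]2[C@H]1n1cnc2c(NCCCF)nc(Cl)nc21`, gives in this assay a value of 72.7 nM.
Compound 3, `CCC(CC)Nc1nc(Cl)nc2c1ncn2[C@H]1[C@H](O)[C@H](O)[C@@H]2C[C@@H]21`, gives in this assay a value of 78.8 nM.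

Compound 3 holds the second highest of the three numbers. Its nearest neighbour is compound 2: the step of a 1.1-fold higher number from compound 2 to compound 3 (0.03 log units; within the scatter) lies within the scatter, so the two cannot be told apart. Its furthest neighbour is compound 1, and the step of a 2.9-fold lower number from compound 1 to compound 3 (0.47 log units; beyond the scatter) is beyond the scatter, as is the parallel step a 3.2-fold lower number from compound 1 to compound 2 (0.50 log units; beyond the scatter).

Compound 4 is `O[C@@H]1[C@H](O)[C@@H]2C[C@@H]2[C@H]1n1cnc2c(NCc3ccccc3F)nc(Cl)nc21`. The change from compound 3 is 2-fluorobenzyl in place of pentan-3-yl on a nitrogen on an aromatic ring. Within the data shown here, no measured step puts an aromatic ring at this nitrogen, so none bears on it directly. The steps that come closest are those from compound 1, where a cycloheptyl was exchanged for a smaller group and the number fell modestly each time; compound 4 moves the other way, toward a larger group. On that basis compound 4 is expected to show a modest rise in this assay, a 1.9-fold higher number from compound 3 to compound 4 (0.28 log units; within the scatter), though the evidence is thin. The estimate for compound 4 in this assay is 150 nM, within a range of 50 nM to 450 nM.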

Compound 4, inhibition constant: 4790 nM
The estimate for compound 4 lay 32-fold (1.50 log units) below the measured number; the measured number lies above the stated range.
By their numbers in this assay, from the lowest: compounds 2 and 3 (each within the scatter of the next); then compound 1; then compound 4.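

Among the groups on this nitrogen, only 2-fluorobenzyl brings an aromatic ring, and it sets compound 4 far apart from the rest in this assay: there is a large rise against pentan-3-yl (a 61-fold higher number from compound 3 to compound 4 (1.78 log units; beyond the scatter)), against 3-fluoropropyl (a 66-fold higher number from compound 2 to compound 4 (1.82 log units; beyond the scatter)) and against cycloheptyl (a 21-fold higher number from compound 1 to compound 4 (1.32 log units; beyond the scatter)). Neither a ring nor a fluorine on this substituent goes with such a high number on its own, as compound 1 also carries a ring and compound 2 also carries a fluorine, yet both stay far lower than compound 4; the position therefore tolerates the three saturated groups far better than this aromatic one. Nothing among the data shown explains why the number rises this far.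

The compounds shown do not separate the aromatic ring from the fluorine on it, so a plain benzyl group would be the informative comparison with compound 4. They also leave open whether a longer link to the ring, as in a 2-phenylethyl group, or a phenyl group set directly on the nitrogen would behave like 2-fluorobenzyl.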